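The source may hold more compounds than are shown below. What is called first, only, known or untested is meant among the compounds shown, and "the series" means these compounds.

Three compounds have been measured in a functional assay on HeLa cells (Homo sapiens) for antiproliferative activity, read by MTT assay, with a stated time of 72 h; on this read-out higher numbers stand for weaker inhibition and lower numbers for stronger inhibition:
compound 1 `O=c1c(SC(=S)N2CCCC2)coc2ccc(Cl)cc12`, which gives 16300 nM;
compound 2 `O=c1c(SC(=S)N2CCCCC2)coc2ccc(Cl)cc12`, which gives 8300 nM;
compound 3 `CCOC(=O)c1cc(=O)c2cc(CSC(=S)N3CCCC3)ccc2o1`, which gives 6600 nM.

Compound 4 `CCOC(=O)c1cc(=O)c2cc(CSC(=S)N3CCCCC3)ccc2o1` has not yet been measured. It differs from compound 3 in one place: piperidin-1-yl in place of pyrrolidin-1-yl on a thiocarbonyl carbon. The same change separates compound 1 from compound 2, (piperidin-1-yl in place of pyrrolidin-1-yl on a thiocarbonyl carbon), and there it produced a 2.0-fold lower number from compound 1 to compound 2 (0.29 log units; within the scatter). How the core of compound 1 differs from the core of compound 3 is not broken down here. The values of compound 2 and compound 3 lie within the scatter of each other, while compound 1 and compound 3 lie beyond it.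

For compound 4 a step of similar, modest size is expected in this assay, namely a 1.5-fold lower number from compound 3 to compound 4 (0.17 log units; within the scatter), because the earlier instance of this change gave a 2.0-fold lower number from compound 1 to compound 2 (0.29 log units; within the scatter). Compound 4 is therefore estimated at 4500 nM, with a likely range from 2000 nM to 10000 nM.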

Compound 4, half-maximal inhibitory concentration: 5800 nM
For compound 4 the middle estimate is 1.3-fold (0.11 log units) below the measured one; the measured number falls inside the stated range.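

In this assay the change to piperidin-1-yl in place of pyrrolidin-1-yl gives a 1.1-fold lower number from compound 3 to compound 4 (0.06 log units; within the scatter) on the core of compound 3. The two instances of this change agree on the two cores: the same change on two cores in this assay, a 2.0-fold lower number (0.29 log units; within the scatter) from compound 1 to compound 2 and a 1.1-fold lower number (0.06 log units; within the scatter) from compound 3 to compound 4, 1.7-fold (0.24 log units) apart, within the scatter of two such steps. This shows that the change carried across these two cores without a step beyond the scatter, but neither step is large enough to show that the change has a real effect on either core, and two pairs say nothing about any further core.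

The compounds shown leave open how other amines on the thiocarbonyl carbon, such as morpholine or dimethylamine, would compare with pyrrolidin-1-yl and piperidin-1-yl. They also leave open which part of the differences between the cores matters in this series.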